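The source may hold more compounds than are shown below. What is called first, only, known or untested is meant among the compounds shown, and "the series" means these compounds.

Series notes, cytotoxicity. Compound 1 `CC(C)C[C@H](NC(=O)OC1CCC(C)(C)CC1)C(=O)N[C@H](C=O)C[C@@H]1CCNC1=O` and compound 3 `CC(C)C[C@H](NC(=O)OC(Cc1ccccc1)C1CCC(F)(F)CC1)C(=O)N[C@H](C=O)C[C@@H]1CCNC1=O` each carry the same change, giving compound 2 `CC(C)C[C@H](NC(=O)OC1CCC(C)(C)CC1)C(=O)N[C@@H](C[C@@H]1CCNC1=O)C(O)S(=O)(=O)O` and compound 4 `CC(C)C[C@H](NC(=O)OC(Cc1ccccc1)C1CCC(F)(F)CC1)C(=O)N[C@@H](C[C@@H]1CCNC1=O)C(O)S(=O)(=O)O`; the difference between the two cores is not broken down here. In an ADME assay on HEK-293T cells (Homo sapiens) for cytotoxicity, with a stated time of 72 h (on this read-out higher numbers stand for lower toxicity in this test and lower numbers for higher toxicity in this test), compound 1 gives > 100000 nM, which is a limit of the test. Compound 2 gives > 100000 nM in this assay, also a limit. The step that the two limits leave unreadable from compound 1 to compound 2 is the change (hydroxy(sulfo)methyl in place of formyl on a saturated chain carbon bound to an amide-type nitrogen and a saturated chain carbon); its size cannot be read because the limit of > 100000 nM in this assay, at which 3 of the 3 values shown sit, holds both of its values. Compound 3 gives > 100000 nM in this assay, again a limit. From compound 3 to compound 4 the change is hydroxy(sulfo)methyl in place of formyl on a saturated chain carbon bound to an amide-type nitrogen and a saturated chain carbon, the same change at the same place as before. For compound 4 a step that the limit leaves unreadable from compound 3 to compound 4 in this assay is expected, resting on (the limit of > 100000 nM in this assay, at which 3 of the 3 values shown sit), where compound 1, compound 2 and compound 3 all sit. Compound 4 is therefore estimated at 150000 nM in this assay, with a range from 80000 nM to 400000 nM, and is most likely to be reported once more as a limit rather than a number.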

Compound 4, half-maximal cytotoxic concentration: > 100000 nM
Compound 4: only a limit was reported; the forecaster's own chance of this, stated with the estimate: 85%; the middle value lies beyond the limit too.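

In this assay compound 4 gives > 100000 nM as a limit of the test. No new step can be read from compound 3 to compound 4, because both values sit at the same limit: the limit of > 100000 nM in this assay, at which 4 of the 4 values shown sit.

The compounds shown leave open how far each lies from that limit, and whether either the formyl to hydroxy(sulfo)methyl change or the difference between the two cores alters cytotoxicity at all.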